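Swapping a Hydroxyethyl Sulfide for a Piperidine Side Chain

This account rests on a few compounds, and the source may have more. Where it says the series, first, only, none or still open, it means among the compounds named here.

In a functional assay on the whole organism with Mus musculus as the target (a higher number here means that more compound is needed for the effect, a lower number that less compound is needed), compound 1 `Cc1c(C)c2c(c(C)c1N)CC(C)(CSc1ccc(O)cc1)O2` gives only a limit, > 50 mg/kg. Compound 2 `Cc1c(C)c2c(c(C)c1N)CC(C)(CSCCO)O2` likewise ends at a limit in this assay, > 50 mg/kg. Among the compounds with values here, the single measured step, a step that the two limits leave unreadable from compound 1 to compound 2, therefore shows neither size nor direction, and the whole evidence is the limit of > 50 mg/kg in this assay, at which 2 of the 2 values shown sit. Compound 3 `Cc1c(C)c2c(c(C)c1N)CC(C)(CCN1CCCCC1)O2` carries (piperidin-1-yl)methyl in place of (2-hydroxyethyl)sulfanyl on a saturated chain carbon bound to a saturated ring carbon. Within the data shown here, no measured step bears on this change, so the numbers give no basis for expecting a move beyond the scatter in either direction. The step expected is an at least 1.6-fold lower number from compound 2 to compound 3 (0.22 log units; that floor lies within the scatter). Compound 3 is estimated at 30 mg/kg, with a range from 5 mg/kg to 100 mg/kg.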

Compound 3, dose for 50% inhibition: 18.4 mg/kg
Compound 3: the middle estimate sits 1.6-fold (0.21 log units) above what was measured; low and high end bracket the measured number.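

Within the data shown here, on a saturated chain carbon bound to a saturated ring carbon, this change gives the first step that can be read in this assay, namely an at least 2.7-fold lower number from compound 2 to compound 3 (0.43 log units; beyond the scatter). With (piperidin-1-yl)methyl in place of (2-hydroxyethyl)sulfanyl, compound 3 gives a measured number rather than a limit. From the compounds shown here alone, the true size of the step stays open, because only a floor can be stated: the limit of > 50 mg/kg in this assay, at which 2 of the 3 values shown sit.

Going by these compounds, whether the ring or its nitrogen matters more also remains open. A cyclohexylmethyl group, with carbon instead of that nitrogen, or an open-chain dimethylamine could help separate the two.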